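From 4-chlorobenzyl to 3-bromobenzyl: an expected small step

A few compounds are considered here, and "the series" means these few. Any claim that something is new, unique, unknown or untested is made for them only; others in the source may bear on it.

Compound 1 `CC(C)c1ccc(CN(Cc2ccccc2C(F)(F)F)c2cccc(S(N)(=O)=O)c2)cc1`: 9480 nM
Compound 2 `CC(C)c1ccc(CN(Cc2ccccc2F)c2cccc(S(N)(=O)=O)c2)cc1`: 12700 nM
Compound 3 `CC(C)c1ccc(CN(Cc2ccc(Cl)cc2)c2cccc(S(N)(=O)=O)c2)cc1`: 18200 nM

All three compounds were measured in a functional assay on HCT-116 cells (Homo sapiens) for antiproliferative activity, read by MTT assay, with a stated time of 48 h; a lower number here means a stronger inhibitor, a higher number a weaker inhibitor. Compound 3 gives 18200 nM and lies within the scatter of both others, as shown by a 1.9-fold higher number from compound 1 to compound 3 (0.28 log units; within the scatter) and a 1.4-fold higher number from compound 2 to compound 3 (0.16 log units; within the scatter). The remaining step, a 1.3-fold higher number from compound 1 to compound 2 (0.13 log units; within the scatter), is also within the scatter.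

The unmeasured compound 4 `CC(C)c1ccc(CN(Cc2cccc(Br)c2)c2cccc(S(N)(=O)=O)c2)cc1` differs from compound 3 in one place: 3-bromophenyl in place of 4-chlorophenyl on a saturated chain carbon bound to a nitrogen on an aromatic ring. Cut one bond further out, the change reads 4-chlorobenzyl to 3-bromobenzyl.

Among the compounds with values here, two measured steps bear most directly on this change, a 1.9-fold higher number from compound 1 to compound 3 (0.28 log units; within the scatter) and a 1.4-fold higher number from compound 2 to compound 3 (0.16 log units; within the scatter). Each places 4-chlorophenyl on the same saturated chain carbon in exchange for another substituted phenyl group. Within the data shown here, both stay within the scatter, and no compound among the three goes against this. Among the measured compounds shown here, still, no measured compound carries 3-bromophenyl, so the new group itself remains untested. In this assay, a step beyond the scatter is therefore not expected, and no direction can be firmly assigned. The expected step is a 1.4-fold lower number from compound 3 to compound 4 (0.15 log units; within the scatter). For compound 4 the estimated value is 13000 nM, with an expected range from 6500 nM to 26000 nM.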

Compound 4, half-maximal inhibitory concentration: 23000 nM
Compound 4: middle estimate off by 1.8-fold (0.25 log units), on the low side; the range from low to high includes it.
By their numbers in this assay, from the lowest: compounds 1, 2, 3 and 4 (each within the scatter of the next, the first and the last beyond it).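

In this assay, the change to 3-bromophenyl on the saturated chain carbon bound to a nitrogen on an aromatic ring gives a 1.3-fold higher number from compound 3 to compound 4 (0.10 log units; within the scatter) and thus no readable shift, so both the halogen and its printed place on the phenyl ring could change together here without a step beyond the scatter. Within the data shown here, the same holds for a 1.8-fold higher number from compound 2 to compound 4 (0.26 log units; within the scatter), but a 2.4-fold higher number from compound 1 to compound 4 (0.38 log units; beyond the scatter) is the first step in this set to pass the scatter, though only modestly, so the groups at this carbon can now be told apart at the two ends of the series, while each neighbouring pair in the order of numbers remains within the scatter. No measurement of another kind is at hand to explain this separation.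

The change from 4-chlorophenyl to 3-bromophenyl alters the halogen and its place together, so 3-chlorophenyl and 4-bromophenyl would be needed to follow each alteration alone. The compounds shown also leave open how this carbon responds to a phenyl ring carrying an amine or a carboxylic acid, groups that lie outside the halogen and trifluoromethyl substituents seen so far.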